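Removing the Amide Methyl from Compound 1

The source may hold more compounds than are shown below. What is called first, only, known or untested is meant among the compounds shown, and "the series" means these compounds.

Compound 1 `CN(C(=O)CSc1nnc(Cc2nn(C)c(=O)c3ccccc23)n1C)c1ccc(Cl)cc1Cl` was tested in an assay on isolated protein (Mus musculus) for inhibition of IL15-IL15 receptor (Homo sapiens), read by resazurin assay, with stated times of 30 min and 2.5 days; on this read-out higher numbers stand for weaker inhibition and lower numbers for stronger inhibition. In this assay compound 1 gives > 30000 nM, which is a limit of the assay rather than a number, as seen from the limit of > 30000 nM in this assay, at which 1 of the 2 values shown sits. Compound 2 `Cn1c(Cc2nn(C)c(=O)c3ccccc23)nnc1SCCCCCCCCCCC(=O)Oc1ccc(Cl)cc1Cl` gives 8700 nM in this assay. Compound 3 `Cn1c(Cc2nn(C)c(=O)c3ccccc23)nnc1SCC(=O)Nc1ccc(Cl)cc1Cl` has not yet been measured; it differs from compound 1 in one place (hydrogen in place of methyl on an amide-type nitrogen). For the measured compounds named here, no measured pair shows this change, so only a modest step is expected, likely within the scatter. Compound 3 is expected to give 25000 nM in this assay, between 6000 nM and 60000 nM. This amounts to an estimated step of an at least 1.2-fold lower number from compound 1 to compound 3 (0.07 log units; that floor lies within the scatter).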

Compound 3, half-maximal inhibitory concentration: 17300 nM
Compound 3: the middle estimate sits 1.4-fold (0.16 log units) above what was measured; the range from low to high includes it.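

In this assay compound 1 gives > 30000 nM, a limit of the assay and not a number. Hydrogen in place of methyl on the amide-type nitrogen gives the first step at this position, though it can be read from one side only, as an at least 1.7-fold lower number from compound 1 to compound 3 (0.23 log units; that floor lies within the scatter). On these data alone, its full size stays unknown because one end of the step is a limit: the limit of > 30000 nM in this assay, at which 1 of the 3 values shown sits.

As far as these compounds go, whether an ethyl group or a longer chain on this nitrogen would read differently from hydrogen and methyl remains open. So does whether this change would give a similar step on another linker.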